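Adding a Nitro Group: a Repeated Change Compared

The compounds below may be only part of what the source reports. "The series", "measured", "known", "first", "only" and "open" are said of these compounds alone.

Compound 1 `Cc1nn(C)c2c(O)nc(-c3ccccc3)nc12` is the parent. Compound 2 `Cc1nn(C)c2c(O)nc(-c3ccc(Cl)cc3)nc12` differs from it by chloro in place of hydrogen on an aromatic carbon, and compound 3 `Cc1nn(C)c2c(O)nc(-c3cccc([N+](=O)[O-])c3)nc12` by nitro in place of hydrogen on an aromatic carbon. In an assay on membranes from brain for binding affinity to adenosine receptor A1 (Rattus norvegicus), read by radioligand binding (on this read-out lower numbers stand for stronger inhibition and higher numbers for weaker inhibition), compound 1 gives 1020 nM, compound 2 gives 410 nM and compound 3 gives 1200 nM. The step of a 2.5-fold lower number from compound 1 to compound 2 (0.40 log units; beyond the scatter); the step of a 1.2-fold higher number from compound 1 to compound 3 (0.07 log units; within the scatter). Compound 4 `Cc1nn(C)c2c(O)nc(-c3ccc(Cl)cc3[N+](=O)[O-])nc12` is not yet measured; it differs from compound 2 by nitro in place of hydrogen on an aromatic carbon. This is the same kind of change as from compound 1 to compound 3, but not the same: there the nitro sat meta to a large group, here it sits ortho to a large group and meta to a chloro group. Because a 1.2-fold higher number from compound 1 to compound 3 (0.07 log units; within the scatter) lay within the scatter, only a small step is expected here, namely a 1.2-fold higher number from compound 2 to compound 4 (0.09 log units; within the scatter). Compound 4 is therefore expected near 500 nM in this assay, between 200 nM and 1500 nM.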

Compound 4, half-maximal inhibitory concentration: 8500 nM
For compound 4 the middle estimate is 17-fold (1.23 log units) below the measured one; the measured number lies above the stated range.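

In this assay, nitro in place of hydrogen gave a 21-fold higher number from compound 2 to compound 4 (1.32 log units; beyond the scatter), so this change does not carry over with the same size from one core to the other: the same change on two cores in this assay, a 1.2-fold higher number (0.07 log units; within the scatter) from compound 1 to compound 3 and a 21-fold higher number (1.32 log units; beyond the scatter) from compound 2 to compound 4, 18-fold (1.25 log units) apart, beyond the scatter of two such steps The small earlier step was therefore a poor guide to this one. The pair does not show why the steps differ: the nitro group sits in a different place in compound 3 and compound 4, and only compound 4 also carries the chloro group, and these two differences cannot be separated here.

Going by these compounds, it remains open whether a nitro group placed as in compound 4 would give a similar step without the chloro group. On these data alone, it is also open whether an amine or a carboxylic acid in that place would give a step of similar size.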